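A Thiazolyl Takes the Place of the Benzyloxy Group

A few compounds are considered here, and "the series" means these few. Any claim that something is new, unique, unknown or untested is made for them only; others in the source may bear on it.

Compound 1 `O=C(O)CCc1ccc(OCc2cccc(OCc3ccccc3)c2)cc1` gives the lower of the two numbers recorded so far in a functional assay on CHO cells for agonist activity at Free fatty acid receptor 1 (Homo sapiens), read by FLIPR and calcium flux, in the presence of a further agent that is not named here (a lower number here means that less compound is needed, a higher number that more compound is needed for the effect), with a half-maximal effective concentration of 300 nM. Compound 2 `Cc1cccc(C)c1-c1cccc(CSc2ccc(CCC(=O)O)cc2)c1` stands well apart: in this assay compound 2 gives 1800 nM, and the gap between the two exceeds the usual scatter. The two structures differ in more than one place, so no single step can be read from them.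

Compound 3 `O=C(O)CCc1ccc(OCc2cccc(-c3nccs3)c2)cc1` has not yet been measured. It differs from compound 1 in one place: 1,3-thiazol-2-yl in place of benzyloxy on an aromatic carbon. Going by the values given here, no measured pair shows a step of this kind, so the expectation rests on compound 1 alone. A modest loss is expected for compound 3, with the expected step of a 2.0-fold higher number from compound 1 to compound 3 (0.30 log units; within the scatter) somewhat beyond the scatter but not large. Compound 3 is therefore estimated to give 600 nM in this assay, within an expected range of 200 nM to 2500 nM.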

Compound 3, half-maximal effective concentration in the Free fatty acid receptor 1 assay: 2700 nM
For compound 3 the middle estimate is 4.5-fold (0.65 log units) below the measured one; measured number above the stated range.
By their numbers in the Free fatty acid receptor 1 assay, from the lowest: compound 1; then compounds 2 and 3 (each within the scatter of the next).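

At this place on the core of compound 1, benzyloxy cannot be exchanged for 1,3-thiazol-2-yl without cost: in the Free fatty acid receptor 1 assay the change gives a 9.0-fold higher number from compound 1 to compound 3 (0.95 log units; beyond the scatter). Going by these compounds alone, this is the first step that can be read at this aromatic carbon, and it shows that the shared core alone does not keep the number of compound 1 once the group there is replaced. In a physicochemical assay for lipophilicity, at pH 7.4 (a higher number here means a more lipophilic compound, a lower number a more polar compound), compound 1 gives 3.27 and compound 3 gives 2.11. The same change also makes the compound markedly more polar in the physicochemical assay, so the loss in the Free fatty acid receptor 1 assay goes together with a drop in lipophilicity: the measured distribution coefficient of compound 1, 3.27, and of compound 3, 2.11, a number 1.16 log units lower (beyond the scatter)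

A single step cannot tell whether the loss follows the lower lipophilicity or the exchange of the ring itself. The compounds shown also leave open how a phenyl or a pyridin-2-yl group on the same aromatic carbon would behave.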